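Methyl on the amine nitrogen of compound 2

This account rests on a few compounds, and the source may have more. Where it says the series, first, only, none or still open, it means among the compounds named here.

Compound 2 `C=C=C(CN)Cc1ccccc1` is one of three allene amines tested in an assay on isolated protein for inhibition of Monoamine oxidase (Rattus norvegicus); a lower number here means a stronger inhibitor, a higher number a weaker inhibitor. Compound 2 gives 20000 nM, the second highest of the three numbers. Compound 1 `C=C=C(Cc1ccccc1)CN(C)C` gives 25000 nM, and the step from compound 1 to compound 2 is a 1.3-fold lower number from compound 1 to compound 2 (0.10 log units; within the scatter). Compound 3 `C=C=C(CN)Cc1ccc(OC)cc1` gives 700 nM, and the step from compound 2 to compound 3 is a 29-fold lower number from compound 2 to compound 3 (1.46 log units; beyond the scatter).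

Compound 4 `C=C=C(CNC)Cc1ccccc1` has not yet been measured in this assay. It differs from compound 2 by methyl in place of hydrogen on an amine nitrogen. Among the compounds with values here, the only measured step that touches the same amine is the one from compound 1 to compound 2, where a dimethylamino was replaced by an amino and the number moved only a 1.3-fold lower number from compound 1 to compound 2 (0.10 log units; within the scatter). The change to compound 4 sits between those two amines, so no step beyond the scatter is expected in this assay; the step from compound 2 to compound 4 is estimated at no change at the digits printed from compound 2 to compound 4 (within the scatter). Compound 4 is therefore expected to give about 20000 nM, within a range from 8000 nM to 50000 nM.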

Compound 4, half-maximal inhibitory concentration: 6200 nM
Beside the measured number, compound 4's estimate is 3.2-fold (0.51 log units) above it, outside the stated range (below it).
By their numbers in this assay, from the lowest: compound 3; then compound 4; then compounds 2 and 1 (each within the scatter of the next).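

In this assay, the amine nitrogen proves sensitive to methyl: adding a single methyl gives a 3.2-fold lower number from compound 2 to compound 4 (0.51 log units; beyond the scatter), and removing one methyl from the dimethylamino group gives a 4.0-fold lower number from compound 1 to compound 4 (0.61 log units; beyond the scatter). The earlier step, a 1.3-fold lower number from compound 1 to compound 2 (0.10 log units; within the scatter), could not show this, as the amino and dimethylamino compounds lie within the scatter of each other, while the methylamino compound stands apart from both. The number therefore does not follow the count of methyls on this nitrogen in a steady line: one methyl gives the lower number, and a second brings it back up.

Nothing available explains why the single methyl matters. Still open, on these data alone, are how an ethyl on the amine nitrogen would compare, and whether the methylamino group and the methoxy on the aromatic carbon would add up in one compound.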